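This account rests on a few compounds, and the source may have more. Where it says the series, first, only, none or still open, it means among the compounds named here.

Measured so far in a functional assay on HCC1937 cells (Homo sapiens) for antiproliferative activity, read by CCK-8 assay, with a stated time of 72 h; on this read-out higher numbers stand for weaker inhibition and lower numbers for stronger inhibition:
- compound 1 `O=C(Nc1cccc(-c2oc3cc(-c4ccc(F)cc4)ccc3c(=O)c2O)c1)c1ccc(F)cc1`: 14200 nM
- compound 2 `Cc1cccc(C(=O)Nc2cccc(-c3oc4cc(-c5ccc(F)cc5)ccc4c(=O)c3O)c2)c1`: 8030 nM

Compound 2 holds the lowest of the two numbers, with compound 1 the nearest; the gap between them, a 1.8-fold lower number from compound 1 to compound 2 (0.25 log units; within the scatter), is within the scatter, so the two cannot be ordered on these data. That single step is also the only one that bears on the next change: it swapped the group on the carbonyl carbon of the amide, 3-methylphenyl in place of 4-fluorophenyl, and moved the number by no more than repeated measurement would.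

Compound 3 `O=C(Nc1cccc(-c2oc3cc(-c4ccc(F)cc4)ccc3c(=O)c2O)c1)c1cc(F)cc(F)c1` carries the change (3,5-difluorophenyl in place of 3-methylphenyl on a carbonyl carbon). Within the data shown here, it is again a substitution of the aryl group on the carbonyl carbon whose other neighbour is the amide-type nitrogen, and the one precedent for such a swap, from compound 1 to compound 2, stayed within the scatter. No step beyond the scatter is therefore expected; if anything, the number is expected to sit between the two measured values. The step from compound 2 to compound 3 is estimated as a 1.2-fold higher number from compound 2 to compound 3 (0.10 log units; within the scatter). For compound 3 the expected value in this assay is 10000 nM, with a range from 4000 nM to 25000 nM.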

Compound 3, half-maximal inhibitory concentration: 2070 nM
The estimate for compound 3 lay 4.8-fold (0.68 log units) above the measured number, and the stated range ends above it.
By their numbers in this assay, from the lowest: compound 3; then compounds 2 and 1 (each within the scatter of the next).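

In this assay the aryl group on the carbonyl carbon whose other neighbour is the amide-type nitrogen proves able to move the number beyond the scatter, with 3,5-difluorophenyl giving a 3.9-fold lower number from compound 2 to compound 3 (0.59 log units; beyond the scatter) against 3-methylphenyl and a 6.9-fold lower number from compound 1 to compound 3 (0.84 log units; beyond the scatter) against 4-fluorophenyl in a series where the earlier swap at this place had stayed within the scatter. Fluorine on this aryl group is not enough by itself: compound 1 carries 4-fluorophenyl and cannot be ordered against compound 2, which has no fluorine there, while compound 3 has the lowest number of the three, with both of its steps beyond the scatter. Nothing at hand accounts for the gain seen with 3,5-difluorophenyl.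

The compounds shown do not separate the number of fluorine atoms from their placement on the aryl group, so a phenyl bearing chlorine, methoxy or trifluoromethyl remains an open comparison at this carbonyl carbon. Also open, on these data alone, is whether a pyridine ring, or a non-aromatic group such as a saturated amine or a carboxylic acid, is tolerated here.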